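Swapping 4-bromophenyl for 2-methoxyphenyl on compound 2

The compounds below may be only part of what the source reports. "The series", "measured", "known", "first", "only" and "open" are said of these compounds alone.

Among the compounds measured in a physicochemical assay for lipophilicity, read by mass spectrometry (on this read-out higher numbers stand for higher lipophilicity and lower numbers for lower lipophilicity), compound 2 `COc1cc2c(cc1OC)C(=O)C(C(=O)Nc1ccc(Br)cc1)C2` stands highest at 3.03. Compound 1 `CCOc1ccc(NC(=O)C2Cc3cc(OC)c(OC)cc3C2=O)cc1` gives 2.42, and compound 3 `CCOc1cccc(NC(=O)C2Cc3cc(OC)c(OC)cc3C2=O)c1` also gives 2.42. Compound 4 `COc1ccccc1NC(=O)C1Cc2cc(OC)c(OC)cc2C1=O` differs from compound 2 in one place: 2-methoxyphenyl in place of 4-bromophenyl on an amide-type nitrogen, with 2-methoxyphenyl in place of 4-bromophenyl on an amide-type nitrogen. For the measured compounds named here, the one measured step that bears on this is a number 0.61 log units higher from compound 1 to compound 2 (beyond the scatter), where a bromo replaces an ethoxy, the reverse sense of the new change. Going by the values given here, no measured compound carries the 2-methoxyphenyl group, so the parallel is loose. A step of similar size in the opposite direction is expected in this assay, namely a number 0.73 log units lower from compound 2 to compound 4 (beyond the scatter), beyond the scatter. For compound 4 the estimate is 2.3, with an expected range from 1.9 to 2.7.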

Compound 4, partition coefficient: 2.08
Beside the measured number, compound 4's estimate is 0.22 log units above it; measured number inside the range.
By their numbers in this assay, from the lowest: compound 4; then compounds 1 and 3 (each within the scatter of the next); then compound 2.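

In this assay, putting 2-methoxyphenyl in place of 4-bromophenyl on the amide-type nitrogen gives a number 0.95 log units lower from compound 2 to compound 4 (beyond the scatter). Together with the earlier step, a number 0.61 log units higher from compound 1 to compound 2 (beyond the scatter), this makes two single changes that each leave compound 2 with the higher number, and here the whole aromatic group changes, not just one substituent on it. No measurement at hand explains the size of this step. Going by these compounds, the swap removes the bromine and brings in the methoxy at once, so their separate shares stay unknown. A plain phenyl group, or a phenyl group carrying a carboxylic acid, could help separate them.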